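Permeability notes on a fused-ring amine series

The source may hold more compounds than are shown below. What is called first, only, known or untested is meant among the compounds shown, and "the series" means these compounds.

Measured so far in an ADME assay for permeability, using PAMPA, with a stated time of 30 min, at pH 7.4; on this read-out lower numbers stand for lower permeability and higher numbers for higher permeability:
compound 1, `CC(C)Cc1ccc2c(NCCCNCc3ccco3)ccnc2c1`, gives 23 10^-6 cm/s;
compound 2, `COc1cccc(CNCCCNc2ccnc3cc(Oc4ccc(Cl)cc4)ccc23)c1O`, gives 317 10^-6 cm/s;
compound 3, `COc1ccc(F)cc1CNCCCNc1ccnc2cc(-c3cccc4ccccc34)ccc12`, gives 237 10^-6 cm/s.

Compound 2 and compound 3 cannot be separated, their gap lying within the scatter; compound 1 sits beyond the scatter below both, so compound 2 stands at the upper end of the three numbers without being set apart from compound 3.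

Compound 4, `COc1cccc(CNCCCNc2ccnc3cc(Cc4cccc(C(F)(F)F)c4)ccc23)c1O`, differs from compound 2 in one place: 3-(trifluoromethyl)benzyl in place of 4-chlorophenoxy on an aromatic carbon. The leaving and the entering groups each carry a single six-membered aromatic ring of carbon only and no hydrogen-bond donor; the entering group carries no hydrogen-bond acceptor. Within the data shown here, no measured pair shows what such a change does in this assay. The expectation is therefore a step of a 1.1-fold lower number from compound 2 to compound 4 (0.05 log units; within the scatter) that does not go beyond the scatter. Compound 4 is estimated at 280 10^-6 cm/s, with a range from 130 10^-6 cm/s to 500 10^-6 cm/s.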

Compound 4, apparent permeability: 23 10^-6 cm/s
Compound 4: middle estimate off by 12-fold (1.09 log units), on the high side, and the stated range ends above it.
By their numbers in this assay, from the lowest: compounds 1 and 4 (each within the scatter of the next); then compounds 3 and 2 (each within the scatter of the next).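

At this aromatic carbon, the group matters in this assay: 3-(trifluoromethyl)benzyl in place of 4-chlorophenoxy gives a 14-fold lower number from compound 2 to compound 4 (1.14 log units; beyond the scatter), although each group carries one six-membered aromatic ring of carbon only and no hydrogen-bond donor. Those shared counts therefore do not keep the number in place for this pair. Nothing measured here accounts for the step.

The compounds shown leave open whether the step follows the change of link to the ring or the change of ring substituent. A chlorobenzyl or a trifluoromethylphenoxy group at this position would separate the two.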